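Carbonyl-ring swaps in a stilbene chalcone series

The source may report more compounds than this note shows. Statements on the series, on what has been measured and on what is new or still open speak of the compounds shown alone.

Values in a functional assay on B16-F10 cells (Mus musculus) for antiproliferative activity, read by MTT assay, with a stated time of 48 h (on this read-out higher numbers stand for weaker inhibition and lower numbers for stronger inhibition), for the measured compounds:
Compound 1 `COc1ccc(/C=C/c2cc(OC)cc(OC)c2/C=C/C(=O)c2ccc(Cl)c(Cl)c2)cc1`: 7.5 ug/mL
Compound 2 `COc1ccc(/C=C/c2cc(OC)cc(OC)c2/C=C/C(=O)c2cccc(Br)c2)cc1`: 5.1 ug/mL
Compound 3 `COc1ccc(/C=C/c2cc(OC)cc(OC)c2/C=C/C(=O)c2ccc(-c3ccccc3)cc2)cc1`: 10.6 ug/mL

Compound 3 stands at the highest of the three numbers in this assay. Its gap to compound 1 is small, a 1.4-fold higher number from compound 1 to compound 3 (0.15 log units; within the scatter), whereas the gap to compound 2 is larger, a 2.1-fold higher number from compound 2 to compound 3 (0.32 log units; beyond the scatter), a modest step that lies beyond the scatter. Compound 4 `COc1ccc(/C=C/c2cc(OC)cc(OC)c2/C=C/C(=O)c2ccc(Cl)cc2)cc1` differs from compound 3 in one place: chloro in place of phenyl on an aromatic carbon. Among the measured compounds shown here, no measured pair makes exactly this change, but all three measured steps alter the same ring on the carbonyl carbon: a 1.5-fold lower number from compound 1 to compound 2 (0.17 log units; within the scatter), a 1.4-fold higher number from compound 1 to compound 3 (0.15 log units; within the scatter) and a 2.1-fold higher number from compound 2 to compound 3 (0.32 log units; beyond the scatter). The two compounds that carry halogens on that ring, compound 1 and compound 2, both sit at lower numbers than compound 3, and the step from compound 2 to compound 3 is the only one beyond the scatter. Compound 4, carrying a single chloro on that ring, is therefore expected to move back toward those two, a modest step in the direction of a lower number, a 1.5-fold lower number from compound 3 to compound 4 (0.18 log units; within the scatter). Compound 4 is estimated at 7 ug/mL, with a range from 3.5 ug/mL to 14 ug/mL.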

Compound 4, half-maximal inhibitory concentration: 4.9 ug/mL
The estimate for compound 4 lay 1.4-fold (0.15 log units) above the measured number, within the range that was stated.
By their numbers in this assay, from the lowest: compounds 4, 2, 1 and 3 (each within the scatter of the next, the first and the last beyond it).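

In this assay, among the compounds shown here, the swap from 4-phenylphenyl to 4-chlorophenyl gives a 2.2-fold lower number from compound 3 to compound 4 (0.34 log units; beyond the scatter), a modest step beyond the scatter and the first direct reading of chloro in place of phenyl on this aromatic carbon. The single chloro does not separate compound 4 from the other two halogen-bearing compounds: the readings are a 1.0-fold lower number from compound 2 to compound 4 (0.02 log units; within the scatter) and a 1.5-fold lower number from compound 1 to compound 4 (0.18 log units; within the scatter), both within the scatter, so neither the 3-bromophenyl ring nor the additional chloro of compound 1 shows a distinct effect in this assay. Nothing available bears on why the exchange of phenyl for chloro shifts the number.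

Whether a halogen is needed at this position remains open, as the compounds shown do not include a methoxy group, an amine or a carboxylic acid there. The unsubstituted phenyl ring, which would set a baseline for all four compounds, is also absent from those shown.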